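The source may report more compounds than this note shows. Statements on the series, on what has been measured and on what is new or still open speak of the compounds shown alone.

Working notes on the series. Two compounds have numbers in an assay on cells for inhibition of sodium- and chloride-dependent glycine transporter 1 (Homo sapiens); on this read-out lower numbers stand for an effect already at smaller amounts and higher numbers for an effect only at larger amounts of compound. Compound 1 `COc1ccc(C2(NC(=O)c3c(OC)cc(C(F)(F)F)cc3SC)CCCN(C)C2)cc1` gives 170 nM in this assay, and compound 2 `COc1cc(C(F)(F)F)cc(SC)c1C(=O)NC1(c2ccncc2)CCCN(C)C1` gives 60 nM. Among the measured compounds shown here, the only step between them, a 2.8-fold lower number from compound 1 to compound 2 (0.45 log units; beyond the scatter), is the one exchange of the group on the saturated ring carbon that has been tried so far. On the two numbers shown, compound 2 stands at the lower one, with compound 1 as its single neighbour at the higher number, the gap being beyond the scatter.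

Compound 3 `COc1cc(C(F)(F)F)cc(SC)c1C(=O)NC1(c2ccc(F)cn2)CCCN(C)C1` is the next compound and is not yet measured in this assay. It differs from compound 2 in 5-fluoropyridin-2-yl in place of pyridin-4-yl on a saturated ring carbon. For the measured compounds named here, the only measured step that bears on this position is a 2.8-fold lower number from compound 1 to compound 2 (0.45 log units; beyond the scatter); it shows that a change of the group on the saturated ring carbon can move the number beyond the scatter, but it does not show the direction for going from pyridin-4-yl to 5-fluoropyridin-2-yl. The expectation for compound 3 is therefore a step of a 1.3-fold higher number from compound 2 to compound 3 (0.12 log units; within the scatter), essentially within the scatter, with wide uncertainty. Compound 3 is estimated at 80 nM, range 25 nM to 260 nM.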

Compound 3, half-maximal effective concentration: 180 nM
The estimate for compound 3 lay 2.3-fold (0.35 log units) below the measured number; low and high end bracket the measured number.
By their numbers in this assay, from the lowest: compound 2; then compounds 1 and 3 (each within the scatter of the next).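

In this assay the exchange on the saturated ring carbon now has a direction away from pyridin-4-yl: 5-fluoropyridin-2-yl gives (a 3.0-fold higher number from compound 2 to compound 3 (0.48 log units; beyond the scatter)), so the advantage of compound 2 over compound 1 does not carry over to this second pyridine-type group. Against 4-methoxyphenyl, 5-fluoropyridin-2-yl gives (a 1.1-fold higher number from compound 1 to compound 3 (0.02 log units; within the scatter)), which leaves compound 1 and compound 3 indistinguishable on this read-out and shows that a ring with one hetero atom at this place is not enough on its own to separate a compound from compound 1; within this set only compound 2 stands apart. No measurement at hand offers an explanation for the difference between pyridin-4-yl and 5-fluoropyridin-2-yl.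

The compounds shown leave open whether the higher number of compound 3 goes with the fluorine or with the change from a pyridin-4-yl to a pyridin-2-yl group, and a plain pyridin-2-yl group on the same ring carbon would bear on that question. Going by these compounds, how a saturated group such as cyclohexyl compares at this place also remains open.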